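Methoxy for hydrogen: compound 3 to compound 4

The source may report more compounds than this note shows. Statements on the series, on what has been measured and on what is new or still open speak of the compounds shown alone.

For the measured compounds named here, compound 3 `COc1ccc(CS(=O)(=O)/C=C/c2c(OC)cccc2OC)cc1` gives 700 nM in a functional assay on DLD-1 cells (Homo sapiens) for antiproliferative activity, read by trypan blue exclusion (a higher number here means a weaker inhibitor, a lower number a stronger inhibitor), the lowest of the three numbers measured so far and well beyond the scatter from both others. Compound 1 `COc1cc(OC)c(/C=C/S(=O)(=O)Cc2ccc(Cl)cc2)c(OC)c1` gives 15000 nM, and compound 2 `COc1cc(OC)c(/C=C/S(=O)(=O)Cc2ccc(C(=O)O)cc2)c(OC)c1` gives 15000 nM; the step of no change at the digits printed from compound 1 to compound 2 (within the scatter) shows that carboxy in place of chloro on an aromatic carbon leaves the number where it was. Compound 4 `COc1ccc(CS(=O)(=O)/C=C/c2c(OC)cc(OC)cc2OC)cc1` differs from compound 3 by methoxy in place of hydrogen on an aromatic carbon. Going by the values given here, no measured step bears directly on this change: compounds 1 and 2 differ from compound 3 in two places at once, so their higher values give only a loose hint that the added methoxy may not help. The expected step of a 2.1-fold higher number from compound 3 to compound 4 (0.33 log units; beyond the scatter) is a modest rise carrying wide uncertainty. Compound 4 is estimated at 1500 nM, within 300 nM to 8000 nM.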

Compound 4, half-maximal inhibitory concentration: 40 nM
Estimate against measurement, compound 4: 38-fold (1.57 log units) above; measured number below the stated range.
By their numbers in this assay, from the lowest: compound 4; then compound 3; then compounds 1 and 2 (each within the scatter of the next).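

Methoxy on the aromatic carbon para to a large group gives an 18-fold lower number from compound 3 to compound 4 (1.24 log units; beyond the scatter) in this assay and so gives this position its first single-change reading, a large gain. The methoxy on the other aromatic ring also counts: it gives a 380-fold lower number from compound 2 to compound 4 (2.57 log units; beyond the scatter) against carboxy and a 380-fold lower number from compound 1 to compound 4 (2.57 log units; beyond the scatter) against chloro, while those two groups sit level with each other. No data at hand explain these steps.

Open, as far as these compounds go, is whether an ethoxy group or an amine on the first carbon keeps the gain. Also open, from the compounds shown here alone, is whether a hydroxyl group or a longer chain can match methoxy on the other ring.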